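Removing the acetyl from an ether-linked side chain

The source may report more compounds than this note shows. Statements on the series, on what has been measured and on what is new or still open speak of the compounds shown alone.

In a functional assay on DU-145 cells (Homo sapiens) for cytotoxicity, read by MTT assay (a higher number here means a weaker inhibitor, a lower number a stronger inhibitor), the measured compounds give these values:
- compound 1, `CC(=O)OCCO[C@H](CC=C(C)C)C1=CC(=O)c2c(O)ccc(O)c2C1=O`: 15500 nM
- compound 2, `CCCCC(CC(=O)O[C@H](CC=C(C)C)C1=CC(=O)c2c(O)ccc(O)c2C1=O)OC(C)=O`: 67700 nM
- compound 3, `CCCC(CC(=O)O[C@H](CC=C(C)C)C1=CC(=O)c2c(O)ccc(O)c2C1=O)OC(C)=O`: 55700 nM

Compound 1 therefore gives the lowest number of the three; compound 3 comes nearest to it and compound 2 lies furthest away, both beyond the usual scatter.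

Compound 4, `CC(C)=CC[C@@H](OCCO)C1=CC(=O)c2c(O)ccc(O)c2C1=O`, is not yet measured. It differs from compound 1 in one place: hydrogen in place of acetyl on an oxygen on a saturated carbon.

For the measured compounds named here, only one measured step is known, a 1.2-fold lower number from compound 2 to compound 3 (0.08 log units; within the scatter). That step shortens a saturated chain on an ester and does not touch an acetyl on an oxygen, so it does not bear on the change from compound 1 to compound 4; it does show that a small edit to a side chain can leave the number unchanged. Going by the values given here, no measured pair here shows what removing an acetyl does.

Among the compounds with values here, with no comparable step in hand, compound 4 is expected to stay close to compound 1, with an estimated step of a 1.3-fold lower number from compound 1 to compound 4 (0.11 log units; within the scatter). The expected value for compound 4 in this assay is 12000 nM, with a likely range from 5000 nM to 30000 nM.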

Compound 4, half-maximal inhibitory concentration: 9900 nM
The estimate for compound 4 lay 1.2-fold (0.08 log units) above the measured number; low and high end bracket the measured number.
By their numbers in this assay, from the lowest: compounds 4 and 1 (each within the scatter of the next); then compounds 3 and 2 (each within the scatter of the next).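

In this assay, exchanging the 2-acetoxyethyl group for 2-hydroxyethyl gives a 1.6-fold lower number from compound 1 to compound 4 (0.19 log units; within the scatter), so the two compounds cannot be told apart in this assay. For the compounds shown here, this is the first measured step at this end of the ether-linked side chain, and it shows that the acetyl, with its 3 heavy atoms, can be lost from the oxygen without a change beyond the scatter, leaving a plain hydroxy group in its place. There is no separate information here on why the number holds when the acetyl goes, so the result describes the outcome and gives no explanation for it.

The compounds shown leave open how much else this position would accept, for example an amine or a carboxylic acid in place of the hydroxy group, or a longer chain between that oxygen and the shared core. As far as these compounds go, it also remains open whether removing the acetyl from the ester-linked side chains of compound 2 and compound 3 would leave their numbers just as unchanged.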